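Ethoxy in place of trifluoromethyl on an aromatic carbon

The compounds below may be only part of what the source reports. "The series", "measured", "known", "first", "only" and "open" are said of these compounds alone.

In a functional assay on the whole organism (strain Sprague-Dawley) for inhibition, with Rattus norvegicus as the target, with a stated time of 10 min (a lower number here means that less compound is needed, a higher number that more compound is needed for the effect), compound 1 `CCOc1cccc(-c2ncc(C(=O)O)c(=O)[nH]2)c1` gives 5 mg/kg as its dose and compound 2 `CCOC(=O)c1cnc(-c2cccc(C(F)(F)F)c2)[nH]c1=O` gives 50 mg/kg as its dose, so compound 2 holds the higher of the two numbers, with a gap beyond the scatter.

The next change is ethoxy in place of trifluoromethyl on an aromatic carbon and it leads to compound 3 `CCOC(=O)c1cnc(-c2cccc(OCC)c2)[nH]c1=O` as the compound awaiting measurement. Within the data shown here, no measured pair isolates this change. Among the measured compounds shown here, the only hint is that compound 1 also carries ethoxy and gives 5 mg/kg as its dose, so a modest move to a lower number in this assay is expected, only just beyond the scatter. The estimated change is a 2.5-fold lower number from compound 2 to compound 3 (0.40 log units; beyond the scatter) and it remains uncertain. Compound 3 is expected at 20 mg/kg as its dose, with 6 mg/kg to 60 mg/kg as the estimated range.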

Compound 3, dose for 50% inhibition: 50 mg/kg
Estimate against measurement, compound 3: 2.5-fold (0.40 log units) below; measured number inside the range.
By their numbers in this assay, from the lowest: compound 1; then compounds 2 and 3 (each within the scatter of the next).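

In this assay, ethoxy in place of trifluoromethyl on an aromatic carbon, meta to a large group, gives no change at the digits printed from compound 2 to compound 3 (within the scatter), so with the ethyl ester present this position does not separate the two groups. With ethoxy held constant, going from the carboxylic acid to its ethyl ester gives a 10-fold higher number from compound 1 to compound 3 (1.00 log units; beyond the scatter), which places the gap seen earlier at the ester rather than at the aromatic group. No measurement here offers an explanation for either step.

On these data alone, whether the two aromatic groups would also match when the carboxylic acid is present remains open, as trifluoromethyl appears here only with the ester. Also open, as far as these compounds go, are a primary amide in place of the acid or ester, and a methoxy group or longer alkoxy chain in place of ethoxy.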